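The source may hold more compounds than are shown below. What is called first, only, known or untested is meant among the compounds shown, and "the series" means these compounds.

The two measured compounds share a core that carries a phenyl and a sulfur-linked side chain. Compound 1 `COc1ccc(-c2nnc(SC/C(=N/O)c3ccccc3)n2-c2ccccc2)cc1` gives 80% in a functional assay on the whole organism (strain albino) for inhibition, with Rattus norvegicus as the target, read by paw edema, with a stated time of 4 h, at a dose of 0.28 mmol/kg by the oral route; a lower number here means less inhibition, a higher number more inhibition at the dose given (going by the name of the read-out). Compound 2 `O=C(CSc1nnc(-c2ccccc2)n1-c1ccccc1)c1ccccc1` gives 68% in this assay; this is the lower of the two numbers, and compound 1 stands higher by a gap beyond the scatter. Among the compounds with values here, the two compounds differ in more than one place, so no single step between them is known; only their two values can be set side by side. Compound 3 `COc1ccc(-c2nnc(SCC(=O)c3ccccc3)n2-c2ccccc2)cc1` has not yet been measured. Its difference from compound 2 is methoxy in place of hydrogen on an aromatic carbon, the methoxy entering on an aromatic carbon of a six-membered aromatic ring of carbon only, para to a large group. Within the data shown here, no measured pair isolates this change, so the size of its effect in this assay is open. Among the measured compounds shown here, because compound 1 as the one measured compound bearing a methoxy gives 80%, a modest rise is expected, a number 6 percentage points higher from compound 2 to compound 3 (within the scatter), though one that may well stay within the scatter. Compound 3 is therefore expected to give 74%, with a range from 62% to 86%.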

Compound 3, a percentage reported as inhibition, in the whole organism at one dose (the size of the read-out at that dose, not a potency): 68%
For compound 3 the middle estimate is 6 percentage points above the measured one; the range from low to high includes it.
By their numbers in this assay, from the lowest: compounds 2 and 3 (each within the scatter of the next); then compound 1.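

Taken on its own for the first time, the change from phenyl to 4-methoxyphenyl, with the methoxy on an aromatic carbon of a six-membered aromatic ring of carbon only, para to a large group, reads as no change at the digits printed from compound 2 to compound 3 (within the scatter) in this assay at the single dose given. Within the data shown here, with the methoxy present in both compounds, the change on the saturated chain carbon bound to a sulfur, an oxime giving way to a carbonyl, reads as a number 12 percentage points lower from compound 1 to compound 3 (beyond the scatter) and is the only one of these two steps that lies beyond the scatter. Among these three compounds, then, the higher number of compound 1 goes with its oxime and not with the methoxy, and nothing shown here gives a reason for either step.

On these data alone, whether the oxime would give a similar gap on the phenyl compound, with no methoxy, remains open. So does the outcome of a different group at this ring position, such as an amine or a carboxylic acid, or of a longer chain between the sulfur and the carbonyl.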